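The source may report more compounds than this note shows. Statements on the series, on what has been measured and on what is new or still open speak of the compounds shown alone.

Within the data shown here, in a functional assay on B16-F10 cells (Mus musculus) for inhibition, read by MTT assay, with a stated time of 72 h (a higher number here means a weaker inhibitor, a lower number a stronger inhibitor), compound 2 `N#Cc1c(Nc2ccc(Cl)cc2)nc(SCc2cn(Cc3ccccc3Cl)nn2)nc1-c1ccccc1` gives 1590 nM, the lowest of the two numbers so far, while compound 1 `N#Cc1c(Nc2ccccc2Cl)nc(SCc2cn(Cc3ccccc3Cl)nn2)nc1-c1ccccc1` gives 8350 nM. Compound 3 `COc1ccccc1Nc1nc(SCc2cn(Cc3ccccc3Cl)nn2)nc(-c2ccccc2)c1C#N` differs from compound 2 by 2-methoxyphenyl in place of 4-chlorophenyl on a nitrogen on an aromatic ring. Among the measured compounds shown here, the one step that bears on this is a 5.3-fold lower number from compound 1 to compound 2 (0.72 log units; beyond the scatter). The 2-methoxyphenyl of compound 3 resembles the 2-chlorophenyl of compound 1 more than the 4-chlorophenyl of compound 2, so a step back toward a higher number is expected, about a 3.1-fold higher number from compound 2 to compound 3 (0.50 log units; beyond the scatter). Compound 3 is therefore estimated at 5000 nM, with a likely range from 1500 nM to 16000 nM.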

Compound 3, half-maximal inhibitory concentration: 7860 nM
Compound 3: the middle estimate sits 1.6-fold (0.20 log units) below what was measured; measured number inside the range.
By their numbers in this assay, from the lowest: compound 2; then compounds 3 and 1 (each within the scatter of the next).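

In this assay 2-methoxyphenyl in place of 4-chlorophenyl gives a 4.9-fold higher number from compound 2 to compound 3 (0.69 log units; beyond the scatter) and methoxy in place of chloro gives a 1.1-fold lower number from compound 1 to compound 3 (0.03 log units; within the scatter) so 2-chlorophenyl and 2-methoxyphenyl cannot be told apart here, while compound 2 with its 4-chlorophenyl keeps the lowest number of the three. Swapping chloro for methoxy on this ring therefore shows no change from 2-chlorophenyl to 2-methoxyphenyl. Nothing measured here explains this result. Still open, as far as these compounds go, is whether 4-methoxyphenyl would match 4-chlorophenyl, and how a plain phenyl would compare.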